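A few compounds are considered here, and "the series" means these few. Any claim that something is new, unique, unknown or untested is made for them only; others in the source may bear on it.

Measured so far in a functional assay on HCT-116 cells (Homo sapiens) for inhibition, read by sulforhodamine B assay, with a stated time of 48 h, tested at 50 uM; a lower number here means less inhibition of growth, a higher number more inhibition of growth at the concentration tested:
- compound 1 `COc1cc2c(cc1CC=C(C)C)/C(=N/NC(N)=O)C[C@@H](c1ccc(O)cc1)O2` gives 87%
- compound 2 `COc1ccc([C@@H]2C/C(=N/OCc3cn(-c4ccccc4CO)nn3)c3cc(CC=C(C)C)c(OC)cc3O2)cc1` gives 100%
- compound 3 `COc1cc2c(cc1CC=C(C)C)C(=O)C[C@@H](c1ccc(Oc3ccccc3)cc1)O2` gives 76%

Compound 3 holds the lowest of the three numbers in this assay. Its nearest neighbour on the numbers is compound 1, whose value sits higher by a margin beyond the scatter; compound 2 lies further away still, also beyond the scatter. For the measured compounds named here, compound 1 and compound 2 each differ from compound 3 in more than one place, so no single step between measured compounds can be drawn, and no part of either gap can be tied to one change.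

Compound 4 `CCOc1ccc([C@@H]2CC(=O)c3cc(CC=C(C)C)c(OC)cc3O2)cc1` has not yet been measured in this assay. It differs from compound 3 at one place:

ethyl in place of phenyl on an oxygen on an aromatic ring

The three measured compounds all carry different groups on that oxygen or in that region, and the two with the higher numbers both differ from compound 3 elsewhere as well, so the direction of the change cannot be read from them. The step is expected to be small, at most modest, and not clearly beyond the scatter in either direction; the expectation for the step is a number 4 percentage points higher from compound 3 to compound 4 (within the scatter). Compound 4 is estimated at 80%, within a range from 62% to 96%.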

Compound 4, percent growth inhibition at one concentration: 65%
Compound 4: middle estimate off by 15 percentage points, on the high side; measured number inside the range.
By their numbers in this assay, from the lowest: compound 4; then compound 3; then compound 1; then compound 2.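

In this assay, the change from phenoxy to ethoxy gives the series its first reading of a single place: ethyl in place of phenyl on this oxygen brings a number 11 percentage points lower from compound 3 to compound 4 (beyond the scatter). The group on the oxygen therefore matters for growth inhibition at the concentration tested, with the phenyl going with the higher number and the ethyl with the lower one, though this rests on a single pair and sets no trend. No measurement at hand explains the step.

On these data alone, whether the number follows anything more general about the group on this oxygen remains open, and a longer chain such as butyl, a benzyl group or a chain ending in an amine at the same place would begin to test that. As far as these compounds go, compound 1 and compound 2 differ from both compound 3 and compound 4 in more than one place, so steps to them cannot be read, and it remains unknown whether the change from phenoxy to ethoxy would carry the same weight on their cores.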